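Plasma half-life: from compound 3 to compound 4

The source may hold more compounds than are shown below. What is called first, only, known or untested is meant among the compounds shown, and "the series" means these compounds.

In an ADME assay on a cell-free system (plasma, Mus musculus) for metabolic stability, read by LC-MS, tested at 2 uM (on this read-out lower numbers stand for a shorter-lived compound and higher numbers for a longer-lived compound), compound 1 `O=C(NCCCCc1ccccc1)n1cc(-c2ccc(F)cc2)oc1=O` gives 1.5 h as a measured number. Compound 2 `COc1cccc(-c2cn(C(=O)NCCCCc3ccccc3)c(=O)o2)c1` reads > 2 h and this is a limit. Compound 3 `COc1cc(-c2cn(C(=O)NCCCCc3ccccc3)c(=O)o2)ccc1F` reads > 2 h and this too is a limit, so it has no number of its own. The series therefore sits largely at one reading: the limit of > 2 h in this assay, at which 2 of the 3 values shown sit, and only compound 1 falls short of it.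

Compound 4 `O=C(NCCCCc1ccccc1)n1cc(-c2ccccn2)oc1=O` carries pyridin-2-yl in place of 4-fluoro-3-methoxyphenyl on an aromatic carbon on the same aromatic carbon of the shared core.

Among the compounds with values here, three measured steps bear on this place. The first is an at least 1.3-fold higher number from compound 1 to compound 2 (0.12 log units; that floor lies within the scatter) and the second is an at least 1.3-fold higher number from compound 1 to compound 3 (0.12 log units; that floor lies within the scatter) and both are floors within the scatter. The third is a step that the two limits leave unreadable from compound 2 to compound 3 and gives no size. Within the data shown here, no measured compound has a hetero atom in this ring.

The expected step is an at least 1.1-fold lower number from compound 3 to compound 4 (0.04 log units; that floor lies within the scatter) and no size beyond the scatter is expected, with the direction left open. For compound 4 the estimated half-life is 1.8 h with an expected range from 0.8 h to 3.5 h in this assay as the next reading.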

Compound 4, half-life: 0.667 h
For compound 4 the middle estimate is 2.7-fold (0.43 log units) above the measured one; measured number below the stated range.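

Pyridin-2-yl gives the first steps at this position that are printed as beyond the scatter in this assay, where all earlier groups here carried a ring of carbon only: an at least 2.9-fold lower number from compound 3 to compound 4 (0.47 log units; beyond the scatter) and an at least 2.9-fold lower number from compound 2 to compound 4 (0.47 log units; beyond the scatter). Within the data shown here, the one step with a measured number at both ends is a 2.2-fold lower number from compound 1 to compound 4 (0.35 log units; beyond the scatter), so the drop also holds against the 4-fluorophenyl group, not only against the two compounds that stand at a limit. The first two steps are floors, and their true size cannot be read: the limit of > 2 h in this assay, at which 2 of the 4 values shown sit.

The compounds shown do not separate the hetero atom in the ring from the loss of the ring's substituents. Plain phenyl or pyridin-3-yl at this place would tell these two apart, and a pyridine ring carrying fluoro or methoxy would test whether either substituent offsets the drop.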